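This account rests on a few compounds, and the source may have more. Where it says the series, first, only, none or still open, it means among the compounds named here.

Two compounds have been measured in a physicochemical assay for lipophilicity, using the shake flask method, in phosphate buffer, measured as octanol-water partition, with a stated time of 30 min, at pH 7.4; on this read-out lower numbers stand for lower lipophilicity and higher numbers for higher lipophilicity:
compound 1, `O=C1CCCN1c1cnc(NCc2c(F)ccc3c2CCO3)n2cnnc12`, gives 1.3;
compound 2, `CN(C)Cc1ccc2c(c1)CN(c1cnc(NCc3c(F)ccc4c3CCO4)c3cn[nH]c(=O)c13)C2=O`, gives 2.2.

Compound 1 stands lowest of the two, and compound 2 sits higher by a margin beyond the usual scatter. Compound 3, `C[C@H]1CC(=O)N(c2cnc(NCc3c(F)ccc4c3CCO4)n3cnnc23)C1`, has not yet been measured. It differs from compound 1 by methyl in place of hydrogen on a saturated ring carbon. For the measured compounds named here, no measured pair shows this kind of change, so the expected step from compound 1 to compound 3 in this assay is taken as a small rise, a number 0.40 log units higher from compound 1 to compound 3 (beyond the scatter), close to the edge of the scatter. Compound 3 is estimated at 1.7, with a likely range from 1.3 to 2.1.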

Compound 3, distribution coefficient: 1.8
Compound 3: the middle estimate sits 0.10 log units below what was measured; low and high end bracket the measured number.
By their numbers in this assay, from the lowest: compound 1; then compound 3; then compound 2.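

In this assay, for the compounds shown here, the change from 2-oxopyrrolidin-1-yl to 4-methyl-2-oxopyrrolidin-1-yl gives a number 0.50 log units higher from compound 1 to compound 3 (beyond the scatter) and is the first step here that can be tied to a single place on the molecule. It shows that one methyl on this saturated ring carbon is enough to produce a modest change in the read-out. Nothing available explains why the number moves at this position.

Going by these compounds, whether an ethyl group, an amine or a carboxylic acid at the same ring carbon would move the number further, or in the opposite direction, remains open. So does whether a methyl on another carbon of this ring would give a similar step.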